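This account rests on a few compounds, and the source may have more. Where it says the series, first, only, none or still open, it means among the compounds named here.

Working notes on the series.

In an assay on HeLa cells for inhibition of Indoleamine 2,3-dioxygenase 1 (Homo sapiens), with a stated time of 24 h (on this read-out higher numbers stand for weaker inhibition and lower numbers for stronger inhibition), compound 1 `O=c1oc2ccc([N+](=O)[O-])cc2n1Cc1ccc(Cl)cc1` gives 99400 nM, and compound 3 `O=C(c1ccccc1)n1c(=O)oc2ccccc21` gives 90500 nM; the two values sit within the scatter of each other, so no order is drawn between them. Compound 2 `O=C(Cc1ccc(F)cc1)n1c(=O)oc2ccccc21` comes out at > 100000 nM in this assay, which is a limit of the assay and not a number; on the numbers shown, compound 2 therefore stands at the top end, as recorded in the limit of > 100000 nM in this assay, at which 1 of the 3 values shown sits. Among the measured compounds shown here, no step between measured compounds is available here, since no pair differs in a single place.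

Compound 4 `O=C(Cc1ccc(F)cc1)n1c(=O)oc2ccc(Cl)cc21` is not yet measured in this assay. It differs from compound 2 by chloro in place of hydrogen on an aromatic carbon, the chloro entering on an aromatic carbon of the fused two-ring core while the hydrogen leaves. With the two other measured compounds, compound 1 at 99400 nM and compound 3 at 90500 nM, lying in the same weak region, no step beyond the scatter is expected from compound 2 to compound 4 in this assay; the estimated step of a number no higher from compound 2 to compound 4 (the limit leaves the size open) is taken as flat. Compound 4 is thus estimated at 100000 nM in this assay, with a range from 40000 nM to 250000 nM, and a fair chance that only a limit is again reported.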

Compound 4, half-maximal inhibitory concentration: 6400 nM
For compound 4 the middle estimate is 16-fold (1.19 log units) above the measured one; measured number below the stated range.
By their numbers in this assay, from the lowest: compound 4; then compounds 3 and 1 (each within the scatter of the next). At a limit, above all of these: compound 2.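

Working from this assay, chloro in place of hydrogen gives an at least 15-fold lower number from compound 2 to compound 4 (1.19 log units; beyond the scatter), the first change at a single place that can be read in this series. Among the compounds shown here, the earlier compounds offered no such step, so this is the first sign that an aromatic carbon of the fused two-ring core, meta to a fused ring and para to a fused ring, can carry a change that moves the read-out beyond the scatter, and here a single heavy atom is enough. Compound 2 stands at a limit of the assay and not a number, so the true size of the step stays open and only its lower bound is known, because the starting point is: the limit of > 100000 nM in this assay, at which 1 of the 4 values shown sits.

The compounds shown leave open whether this drop belongs to chloro itself or would also appear with another group at the same place, such as fluoro, methoxy, an amine or a carboxylic acid. They also leave open whether the same change would give a step of similar size on compound 3, which carries a different group on the ring nitrogen of the shared core.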